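Sulfanyl to Sulfonyl on a Shared Amide Scaffold

The source may report more compounds than this note shows. Statements on the series, on what has been measured and on what is new or still open speak of the compounds shown alone.

The measured compounds are these:

compound 1, `O=C(Nc1cc(C(F)(F)F)ccc1C(F)(F)F)c1ccc(Sc2ccc(O)cc2)cc1`, 10300 nM
compound 2, `O=C(Nc1ccc(S(F)(F)(F)(F)F)cc1)c1ccc(Sc2ccc(O)cc2)cc1`, 3710 nM
compound 3, `O=C(Nc1cc(C(F)(F)F)ccc1C(F)(F)F)c1ccc(S(=O)(=O)c2ccc(O)cc2)cc1`, 20700 nM

All three were tested in a functional assay on CWR22R cells (Homo sapiens) for antiproliferative activity, read by fluorescence and propidium iodide staining, with a stated time of 96 h; a lower number here means a stronger inhibitor, a higher number a weaker inhibitor. Compound 2 gives the lowest number of the three, 3710 nM, and its steps to compound 1 and to compound 3 are both beyond the usual scatter of this assay. Compound 1 gives 10300 nM, and compound 3, which carries the change ((4-hydroxyphenyl)sulfonyl in place of (4-hydroxyphenyl)sulfanyl on an aromatic carbon), gives 20700 nM. Going by the values given here, the step of a 2.0-fold higher number from compound 1 to compound 3 (0.30 log units; within the scatter) is the only directly comparable pair among the measured compounds. The difference between the cores of compound 1 and compound 2 is not broken down here.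

Compound 4, `O=C(Nc1ccc(S(F)(F)(F)(F)F)cc1)c1ccc(S(=O)(=O)c2ccc(O)cc2)cc1`, has not yet been measured in this assay. It relates to compound 2 exactly as compound 3 relates to compound 1: the change is (4-hydroxyphenyl)sulfonyl in place of (4-hydroxyphenyl)sulfanyl on an aromatic carbon, and the two changes sit in the same place, so they are the same change. Among the compounds with values here, the only guide to its size is the step from compound 1 to compound 3, which raised the number somewhat but stayed inside the scatter. The same kind of step, a 2.0-fold higher number from compound 2 to compound 4 (0.30 log units; within the scatter), is expected from compound 2 to compound 4, resting on the step of a 2.0-fold higher number from compound 1 to compound 3 (0.30 log units; within the scatter) and on the value that compound 2 gives, 3710 nM. Compound 4 is therefore estimated to give 7400 nM in this assay, with a likely range from 3000 nM to 18000 nM.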

Compound 4, half-maximal inhibitory concentration: 5780 nM
Compound 4: middle estimate off by 1.3-fold (0.11 log units), on the high side, within the range that was stated.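

In this assay, putting (4-hydroxyphenyl)sulfonyl in place of (4-hydroxyphenyl)sulfanyl on the core of compound 2 gives a 1.6-fold higher number from compound 2 to compound 4 (0.19 log units; within the scatter), a step that reads in the same direction as the one seen on the core of compound 1 but is too small to count as an effect on its own. Set side by side, the two steps do not differ, so on these two cores the change carries over with no detectable dependence on the core: the same change on two cores in this assay, a 2.0-fold higher number (0.30 log units; within the scatter) from compound 1 to compound 3 and a 1.6-fold higher number (0.19 log units; within the scatter) from compound 2 to compound 4, 1.3-fold (0.11 log units) apart, within the scatter of two such steps. This agreement does not show that the change has a real effect on either core, since each step lies within the scatter, and two cores are too few to support a rule for the wider series or to say anything about why the numbers fall as they do.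

The compounds shown all keep the 4-hydroxyphenyl group and a sulfur link at this place, so it remains open how the picture would look with a sulfinyl link, an oxygen or methylene link, or a methoxy group or an amine in place of the hydroxyl. Also open, on these data alone, is whether the step would hold on a core bearing a nitrile or a single trifluoromethyl group in place of the fluorinated groups of compound 1 and compound 2.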